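Replacing 3,4-dichlorophenyl with 2,4-difluorophenyl

The source may hold more compounds than are shown below. What is called first, only, known or untested is meant among the compounds shown, and "the series" means these compounds.

Measured so far in a functional assay on SW-620 cells (Homo sapiens); a lower number here means a stronger inhibitor of growth, a higher number a weaker inhibitor of growth
compound 1 `O=S(=O)(/C=C/c1ccccc1)Cc1ccc(Nc2ncnc3ccccc23)cc1` gives > 100000 nM
compound 2 `O=S(=O)(/C=C/c1ccc(Cl)c(Cl)c1)Cc1ccc(Nc2ncnc3ccccc23)cc1` gives 41000 nM

Compound 1 stands at > 100000 nM as a limit and not a number. Among the measured compounds shown here, compound 2 gives 41000 nM as the only number. Compound 3 `O=S(=O)(/C=C/c1ccc(F)cc1F)Cc1ccc(Nc2ncnc3ccccc23)cc1` departs from compound 2 by 2,4-difluorophenyl in place of 3,4-dichlorophenyl on a double-bonded chain carbon bound to a double-bonded chain carbon at that one place. For the measured compounds named here, the single measured step at this place is an at least 2.4-fold lower number from compound 1 to compound 2 (0.38 log units; beyond the scatter) and it rests on a limit. With 3,4-dichlorophenyl leaving, part of that step is expected to be lost, so a modest move to a higher number is expected in this assay as a 1.8-fold higher number from compound 2 to compound 3 (0.26 log units; within the scatter) for this change. Compound 3 is estimated at 75000 nM with an expected range from 30000 nM to 180000 nM overall.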

Compound 3, concentration for 50% growth inhibition: 86000 nM
Compound 3: middle estimate off by 1.1-fold (0.06 log units), on the low side; the range from low to high includes it.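

In this assay, the change gives a 2.1-fold higher number from compound 2 to compound 3 (0.32 log units; beyond the scatter), so two halogens on the phenyl do not by themselves carry the number of compound 2; the identity or placement of the halogens matters at this place. The comparison with phenyl gives an at least 1.1-fold lower number from compound 1 to compound 3 (0.06 log units; that floor lies within the scatter), which does not separate compound 3 from compound 1. That comparison rests on the limit of compound 1, which is a limit and not a number: the limit of > 100000 nM in this assay, at which 1 of the 3 values shown sits.

From the compounds shown here alone, whether halogen identity or placement drives the step stays open, and 3,4-difluorophenyl would separate the two. Going by these compounds, the effect of an aminophenyl or a carboxyphenyl at this place is also open.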